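This account rests on a few compounds, and the source may have more. Where it says the series, first, only, none or still open, it means among the compounds named here.

Compound 1 `N[C@@H](COP(=O)(O)OC[C@H]1OCC=C[C@H]1OC(=O)CCc1ccccc1OCc1cccc(Oc2ccccc2)c1)C(=O)O` was tested in an assay on HEK293-A cells for agonist activity at putative P2Y purinoceptor 10 (Mus musculus), with a stated time of 1.5 h (a higher number here means a larger maximal response, a lower number a smaller maximal response), and there compound 1 gives "not active" (no number reported), so no single number stands for it. A second compound, compound 2 `CCCCCCCCCCCOc1ccccc1CCC(=O)OCc1cccc(OP(=O)(O)OC[C@H](N)C(=O)O)c1`, shares the phosphoserine part but carries a different linker and a long chain; in this assay compound 2 gives 10.8%, a small response. Compound 3 `N[C@@H](COP(=O)(O)OC[C@H]1OCC=C[C@@H]1OC(=O)CCc1ccccc1OCc1cccc(Oc2ccccc2)c1)C(=O)O` has not yet been measured. Its relation to compound 1 is the two compounds have the same atoms and bonds; at least one stereo element is drawn with a configuration in one of them and without one in the other: 1 of 4 stereo elements differ; a stereocentre at a saturated ring carbon is drawn R in compound 1 and S in compound 3. Among the compounds with values here, with no measured pair in this set that differs only in a stereocentre, there is nothing to show how large a step such a change brings in this assay; because compound 1 gives "not active" (no number reported), the most that can be said is that any change is expected to be small and toward a low response, likely within the scatter or only modestly beyond it. Compound 3 is therefore estimated at 10%, with a range from 0% to 35%.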

Compound 3, largest response reached (Emax), in percent of the reference or control that the assay uses: "not active" (no number reported)
Compound 3 has no reported number here, so the estimate cannot be set against anything.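

In this assay compound 1 gives "not active" (no number reported) and compound 3 gives "not active" (no number reported), so no step can be read between these two compounds. Their single difference therefore has no size here: the fact that one of compounds 1 and 3 is drawn with a defined configuration and the other without, at the place where they differ. The compounds shown leave open whether changing this stereocentre alters the response in this assay at all.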